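The source may hold more compounds than are shown below. What is called first, only, known or untested is meant among the compounds shown, and "the series" means these compounds.

Compound 1 `CCc1ccc(SCc2ccc(/C=C/C(=O)Nc3ccccc3N)cc2)cc1`: 60.7%
Compound 2 `Cc1ccc(SCc2ccc(C(=O)Nc3ccccc3N)cc2)cc1`: 40.5%

In a functional assay on A549 cells (Homo sapiens) for inhibition, read by CCK-8 assay, with a stated time of 72 h, tested at 2 uM (on this read-out higher numbers stand for more inhibition of growth at the one concentration tested and lower numbers for less inhibition of growth), compound 1 gives 60.7% and compound 2 gives 40.5%. The gap between these two numbers lies beyond the scatter, and compound 1 has the higher number. These two compounds differ in more than one place, so neither value isolates the change made next. Compound 3 `Nc1ccccc1NC(=O)/C=C/c1ccc(CSc2cccc3ccccc23)cc1` has naphthalen-1-yl in place of 4-ethylphenyl on a sulfur. Among the measured compounds shown here, no measured pair shows this change, so no shift beyond the scatter is expected in this assay. The expected step is small, a number 5.7 percentage points lower from compound 1 to compound 3 (within the scatter). For compound 3 the estimated value is 55%, with an expected range of 37% to 73%.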

Compound 3, percent growth inhibition at one concentration: 59.3%
Estimate against measurement, compound 3: 4.3 percentage points below; the range from low to high includes it.
By their numbers in this assay, from the lowest: compound 2; then compounds 3 and 1 (each within the scatter of the next).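

In this assay, placing naphthalen-1-yl in place of 4-ethylphenyl on the sulfur gives a number 1.4 percentage points lower from compound 1 to compound 3 (within the scatter), the only single-place step shown. At this position, a group with 2 six-membered aromatic rings therefore reads the same, within the scatter, as a group with one. Nothing available explains this result. As far as these compounds go, it remains open how an amine, a carboxylic acid or a longer chain at this position would read. Compound 2 differs from compound 1 in more than one place, so its lower value cannot be assigned to any single change.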